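The source may report more compounds than this note shows. Statements on the series, on what has been measured and on what is new or still open speak of the compounds shown alone.

Compound 1, `c1ccc(-c2ccncn2)c(OCC2=NCCN2)c1`: in a functional assay for activation of Alpha-1B adrenergic receptor (Homo sapiens), read by calcium flux (on this read-out higher numbers stand for an effect only at larger amounts of compound and lower numbers for an effect already at smaller amounts), compound 1 gives < 100000 nM, which is a limit of the assay and not a number.
Compound 2, `c1ccc(-c2ncc[nH]2)c(OCC2=NCCN2)c1`: in this assay compound 2 gives < 100000 nM, again a limit.
Compound 3, `Cc1ccoc1-c1ccccc1OCC1=NCCN1`: in this assay compound 3 gives < 100000 nM, also a limit.

Compound 3 therefore stands nowhere in particular on the numbers shown: its value is a limit, and the two other values sit at the same limit (the limit of < 100000 nM in this assay, at which 3 of the 3 values shown sit). The steps that lead to it, a step that the two limits leave unreadable from compound 1 to compound 3 and a step that the two limits leave unreadable from compound 2 to compound 3, are accordingly unreadable, as is a step that the two limits leave unreadable from compound 1 to compound 2.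

Compound 4, `Cn1nccc1-c1ccccc1OCC1=NCCN1`, differs from compound 3 in one place: 1-methyl-1H-pyrazol-5-yl in place of 3-methylfuran-2-yl on an aromatic carbon. Every measured exchange of the five- or six-membered aromatic group on that carbon left the read-out at the limit, so none of the three steps gives a size to carry over to this one. Going by the values given here, the expectation for a step that the limit leaves unreadable from compound 3 to compound 4 is thus only that no readable step appears, in either direction. Compound 4 is estimated at 20000 nM in this assay, with a range from 2000 nM to 100000 nM, and most likely the assay again reports only a limit.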

Compound 4, half-maximal effective concentration: < 100000 nM
Compound 4 was reported as a limit; the forecaster's own chance of this, stated with the estimate: 70%; the middle value lies beyond the limit too.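

In this assay compound 4 gives < 100000 nM as a limit of the assay and not a number. Its steps from compound 1, compound 2 and compound 3 therefore cannot be read: the limit of < 100000 nM in this assay, at which 4 of the 4 values shown sit.

The compounds shown leave open whether any aromatic group on that carbon gives a value clear of the limit, and how large a step between such groups would be.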